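Phenyl in Place of sec-Butyl on a Shared Core

The source may hold more compounds than are shown below. What is called first, only, known or untested is meant among the compounds shown, and "the series" means these compounds.

Compound 1 `CCC(C)C1NC(=O)N(C2CCCC2)C1=O` stands, in a functional assay on MIA PaCa-2 cells (Homo sapiens) for inhibition (on this read-out higher numbers stand for weaker inhibition and lower numbers for stronger inhibition), at a limit of the assay: compound 1 gives > 100000 nM. Among the three measured values, the limit of > 100000 nM in this assay, at which 2 of the 3 values shown sit, shows where most of them sit. Compound 3 `CCC(C)C(NC(=O)NO)C(=O)NCc1ccccc1` also sits at a limit in this assay, giving > 100000 nM. Among the compounds with values here, compound 2 `CCC(C)C(NC(=O)n1nnc2ccccc21)C(=O)NC(c1ccccc1)c1ccccc1` is the one measured compound with a number rather than a limit, giving 69300 nM in this assay. Compound 1 can therefore not be ranked against compound 3 on these numbers; only compound 2 offers a value to compare with.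

Compound 4 `O=C1NC(c2ccccc2)C(=O)N1C1CCCC1` has not been measured. It differs from compound 1 by phenyl in place of sec-butyl on a saturated ring carbon; in words, phenyl in place of sec-butyl on a saturated ring carbon. Within the data shown here, no pair among the measured compounds shows this change, so no measured step indicates its size or direction. With compound 1 at a limit, the numbers give no reason to expect a move beyond the scatter in either direction. Compound 4 is therefore expected to remain near the limit, with an expected step of a number no higher from compound 1 to compound 4 (the limit leaves the size open) amounting to none beyond the scatter. The estimate for compound 4 in this assay is 100000 nM, between 30000 nM and 300000 nM.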

Compound 4, half-maximal inhibitory concentration: > 100000 nM
Compound 4: only a limit was reported; the forecaster's own chance of this, stated with the estimate: 70%; the middle value sits exactly at the limit.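

In this assay compound 4 gives > 100000 nM, a limit of the assay, and compound 1 is also reported only as a limit, so no step can be read between compound 1 and compound 4. That limit now holds most of the values: the limit of > 100000 nM in this assay, at which 3 of the 4 values shown sit. The compounds shown leave open whether phenyl in place of sec-butyl changes inhibition at all, and in which direction.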